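A butyl chain in place of tert-butyl

The source may hold more compounds than are shown below. What is called first, only, known or untested is meant among the compounds shown, and "the series" means these compounds.

Measured in an ADME assay on liver for metabolic stability, with Liver microsome (Homo sapiens) as the target, read by LC-MS, using microsomes; on this read-out higher numbers stand for fast clearance and lower numbers for slow clearance:
- compound 1 `O=C(NCc1cc(Cl)ccc1-n1cnnn1)[C@@H]1C[C@H]2C[C@H]2N1C(=O)[C@H](O)c1ccccc1`: < 15 mL.min-1.g-1, a limit
- compound 2 `CC(C)(C)C[C@@H](O)C(=O)N1[C@@H]2C[C@@H]2C[C@H]1C(=O)NCc1cc(Cl)ccc1-n1cnnn1`: 71 mL.min-1.g-1
- compound 3 `CC(C)(C)[C@@H](O)C(=O)N1[C@@H]2C[C@@H]2C[C@H]1C(=O)NCc1cc(Cl)ccc1-n1cnnn1`: 54 mL.min-1.g-1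

Among the measured compounds shown here, compound 3 stands level with compound 2, as the only other compound with a number. The step between them is a 1.3-fold lower number from compound 2 to compound 3 (0.12 log units; within the scatter).

Compound 4 `CCCC[C@@H](O)C(=O)N1[C@@H]2C[C@@H]2C[C@H]1C(=O)NCc1cc(Cl)ccc1-n1cnnn1` carries one change: butyl in place of tert-butyl on a saturated chain carbon bound to a carbonyl carbon and an oxygen on a saturated carbon, butyl in place of tert-butyl. Two steps at this place start from the limit and replace phenyl: an at least 4.7-fold higher number from compound 1 to compound 2 (0.67 log units; beyond the scatter) and an at least 3.6-fold higher number from compound 1 to compound 3 (0.55 log units; beyond the scatter). For the measured compounds named here, the closest precedent is the exchange of one four- or five-carbon group for another, a 1.3-fold lower number from compound 2 to compound 3 (0.12 log units; within the scatter), though no measured compound carries butyl. The expected step is a 1.4-fold higher number from compound 3 to compound 4 (0.14 log units; within the scatter), so none beyond the scatter is anticipated. Compound 4 is expected at 75 mL.min-1.g-1, with an estimated range of 35 mL.min-1.g-1 to 160 mL.min-1.g-1.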

Compound 4, intrinsic clearance in microsomes: 89 mL.min-1.g-1
Compound 4: middle estimate off by 1.2-fold (0.07 log units), on the low side; measured number inside the range.
By their numbers in this assay, from the lowest: compounds 3, 2 and 4 (each within the scatter of the next). At a limit, below all of these: compound 1.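

In this assay, swapping tert-butyl for the straight butyl chain at this position changes little: a 1.6-fold higher number from compound 3 to compound 4 (0.22 log units; within the scatter), and against the neopentyl compound the picture is the same, a 1.3-fold higher number from compound 2 to compound 4 (0.10 log units; within the scatter). The arrangement of the saturated chain therefore does not separate these compounds, while all three stand apart from the phenyl compound, as with an at least 5.9-fold higher number from compound 1 to compound 4 (0.77 log units; beyond the scatter). Compound 1 gives only a limit: the limit of < 15 mL.min-1.g-1 in this assay, at which 1 of the 4 values shown sits.

From the compounds shown here alone, the size of the gap to phenyl therefore stays open. So does whether a cyclohexyl or benzyl group would read with the saturated chains or with phenyl.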